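Benzyloxy analogue of a chloroquinoline cytotoxicity series

The source may hold more compounds than are shown below. What is called first, only, known or untested is meant among the compounds shown, and "the series" means these compounds.

Measured compounds in a functional assay on BGC-823 cells (Homo sapiens) for cytotoxicity, read by MTT assay, with a stated time of 48 h; a higher number here means a weaker inhibitor, a lower number a stronger inhibitor: compound 1 `CCOc1ccc2c(Cl)ccnc2c1` gives 3910 nM; compound 2 `CC(C)Oc1ccc2c(Cl)ccnc2c1` gives 2630 nM; compound 3 `CCOc1ccc2c(NCCN(C)C)ccnc2c1` gives 2520 nM.

Compound 1 has the highest number of the three, but its steps to compound 2 and to compound 3 both sit within the scatter, so the three are not separable. Compound 4 `Clc1ccnc2cc(OCc3ccccc3)ccc12` differs from compound 1 by phenyl in place of methyl on a saturated chain carbon bound to an oxygen on an aromatic ring. Going by the values given here, the only step at the same place is a 1.5-fold lower number from compound 1 to compound 2 (0.17 log units; within the scatter), a small change within the scatter; the step of a 1.6-fold lower number from compound 1 to compound 3 (0.19 log units; within the scatter) is at a different place and bears less. Phenyl is larger than methyl, so a somewhat larger move is possible, but no direction can be read from these steps. Compound 4 is therefore expected near compound 1, with a 1.6-fold lower number from compound 1 to compound 4 (0.19 log units; within the scatter); the estimate is 2500 nM, within 800 nM to 8000 nM.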

Compound 4, half-maximal inhibitory concentration: 5170 nM
Estimate against measurement, compound 4: 2.1-fold (0.32 log units) below; the measured number falls inside the stated range.
By their numbers in this assay, from the lowest: compounds 3, 2, 1 and 4 (each within the scatter of the next, the first and the last beyond it).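

Phenyl in place of methyl on a saturated chain carbon bound to an oxygen on an aromatic ring brings in a six-membered aromatic ring, yet the step (a 1.3-fold higher number from compound 1 to compound 4 (0.12 log units; within the scatter)) stays within the scatter. This place therefore accepts an aromatic ring as well as the added methyl of compound 2 without a separable shift in cytotoxicity. No available measurement accounts for this result.

Open, from the compounds shown here alone, is whether an amine, a carboxylic acid or a longer chain at this place would move the number beyond the scatter. Also open, going by these compounds, is how (2-(dimethylamino)ethyl)amino in place of chloro would behave on the core of compound 4.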